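Aryl Replacement on the Five-Membered Ring: Compound 4

A few compounds are considered here, and "the series" means these few. Any claim that something is new, unique, unknown or untested is made for them only; others in the source may bear on it.

Three compounds have been measured in a functional assay on the whole organism for inhibition, with Mythimna separata as the target, with a stated time of 5 days; a higher number here means that more compound is needed for the effect, a lower number that less compound is needed:
Compound 1 `CC(C)(C)n1ncc(OCc2nnc(-c3ccc(Cl)cc3)s2)c(Cl)c1=O`: 106 ug/mL
Compound 2 `CC(C)(C)n1ncc(OCc2nnc(-c3cc(F)c(Cl)cc3Cl)s2)c(Cl)c1=O`: 67.1 ug/mL
Compound 3 `CC(C)(C)n1ncc(OCc2nnc(-c3cc(F)c(F)c(F)c3F)o2)c(Cl)c1=O`: 241 ug/mL

Compound 2 stands lowest of the three. Its nearest neighbour is compound 1, with a 1.6-fold lower number from compound 1 to compound 2 (0.20 log units; within the scatter); its furthest is compound 3, whose number lies beyond the scatter above that of compound 2. Compound 4 `Cc1cccc(-c2nnc(COc3cnn(C(C)(C)C)c(=O)c3Cl)s2)c1` differs from compound 2 in one place: 3-methylphenyl in place of 2,4-dichloro-5-fluorophenyl on an aromatic carbon. For the measured compounds named here, the only measured step that bears on this position is the one from compound 1 to compound 2, and it stayed within the scatter, so in this assay a step of no more than modest size is expected for compound 4, most likely upward toward compound 1, as a 1.6-fold higher number from compound 2 to compound 4 (0.21 log units; within the scatter). Compound 4 is therefore estimated at 110 ug/mL, with a range from 45 ug/mL to 300 ug/mL.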

Compound 4, half-maximal effective concentration: > 300 ug/mL
Compound 4: only a limit was reported; the forecaster's own chance of this, stated with the estimate: 10%; middle value at least 2.7-fold (0.43 log units) from the limit.
By their numbers in this assay, from the lowest: compounds 2 and 1 (each within the scatter of the next); then compound 3. At a limit, above all of these: compound 4.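

In this assay the aryl group on the five-membered ring proves less tolerant of change than the earlier step suggested, as 3-methylphenyl gives an at least 4.4-fold higher number from compound 2 to compound 4 (0.65 log units; beyond the scatter) and an at least 2.8-fold higher number from compound 1 to compound 4 (0.45 log units; beyond the scatter). Going by these compounds, compound 4 gives > 300 ug/mL, which is a limit of the assay and not a number, so the full size of both steps stays unknown. Compound 1 and compound 2 both carry chlorine on the phenyl ring, and compound 4 carries none.

The compounds shown do not separate the effect of adding methyl from that of losing chlorine. On these data alone, how an unsubstituted phenyl, a methoxyphenyl or an aminophenyl would fare at this position remains open.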